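The compounds below may be only part of what the source reports. "The series", "measured", "known", "first", "only" and "open" are said of these compounds alone.

Working notes on the series. Among the compounds with values here, compound 1 `CC(C)(C)C1=NN(c2ccc(C(F)(F)F)cc2)C(c2ccc(O)cc2)C1` is the one member with a number: in an assay on isolated protein for inhibition of protein kinase C zeta type (Homo sapiens), with a stated time of 4 min (a lower number here means a stronger inhibitor, a higher number a weaker inhibitor), compound 1 gives 8800 nM. Within the data shown here, compound 2 `CC(C)(C)C1=NN(c2ccccc2Cl)C(c2ccc(O)cc2)C1`, which carries a 2-chlorophenyl on the ring nitrogen of the shared core, has no result in this assay; for compound 2 the record reads "not determined" (no result reported), so compound 2 stands nowhere on the numbers so far and gives no anchor of its own. Compound 3 `CC(C)(C)C1=NN(c2ccc(F)c(Cl)c2)C(c2ccc(O)cc2)C1` is the next member to be tested. The change from compound 2 to compound 3 is 3-chloro-4-fluorophenyl in place of 2-chlorophenyl on an amine nitrogen in a ring. Among the measured compounds shown here, no measured step connects these two, and the only number is that of compound 1, which carries a different substituted phenyl at the same ring nitrogen. Without a measured pair sharing this change, the step from compound 2 to compound 3 in this assay cannot be sized; no movement beyond the usual scatter is expected in either direction, and the estimate leans on compound 1 with 8800 nM as the nearest measured analogue. Compound 3 is expected to give about 8000 nM in this assay, within a range from 2500 nM to 25000 nM.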

Compound 3, half-maximal inhibitory concentration: 900 nM
Beside the measured number, compound 3's estimate is 8.9-fold (0.95 log units) above it; measured number outside the range, below it.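

No new step can be read here: compound 2 and compound 3 do not form a pair with two numbers in this assay. Nothing on hand bears on the result for compound 3. The compounds shown leave open how much the change from 2-chlorophenyl to 3-chloro-4-fluorophenyl on the ring nitrogen moves inhibition.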